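The source may hold more compounds than are shown below. What is called first, only, known or untested is meant among the compounds shown, and "the series" means these compounds.

Compound 1, with the structure `O=C(CO[N+](=O)[O-])NNC(=O)c1ccc(-n2[nH]c(=O)cc2-c2ccccc2O)cc1`, was tested in a functional assay on the whole organism (strain Wistar) for inhibition, with Rattus norvegicus as the target, read by paw edema, with stated times of 3 h and 1 h, at a dose of 6 mg/kg by the oral route (a lower number here means less inhibition, a higher number more inhibition at the dose given (going by the name of the read-out)), where compound 1 gives 16.4%. Compound 2, with the structure `O=C(CO[N+](=O)[O-])NNC(=O)c1ccc(-n2[nH]c(=O)cc2-c2ccc(Cl)cc2)cc1`, differs from compound 1 in one place: 4-chlorophenyl in place of 2-hydroxyphenyl on an aromatic carbon With this change the read-out moved a number 10.6 percentage points lower from compound 1 to compound 2 (beyond the scatter), so that compound 2 gives 5.84% in this assay.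

Compound 3, with the structure `CCOC(=O)c1c(-c2ccccc2O)n(-c2ccc(C(=O)NNC(=O)CO[N+](=O)[O-])cc2)[nH]c1=O`, carries a different core than compound 1; the difference is ethoxycarbonyl in place of hydrogen on an aromatic carbon This change gave a number 4.7 percentage points higher from compound 1 to compound 3 (within the scatter), and compound 3 gives 21.1% in this assay. Of the three measured numbers that of compound 3 is the highest, but its gap to compound 1 lies within the usual scatter.

Compound 4, with the structure `CCOC(=O)c1c(-c2ccc(Cl)cc2)n(-c2ccc(C(=O)NNC(=O)CO[N+](=O)[O-])cc2)[nH]c1=O`, has not yet been measured. It differs from compound 3 by 4-chlorophenyl in place of 2-hydroxyphenyl on an aromatic carbon This is the same kind of change as that from compound 1 to compound 2, though here the place is also next to the ring atom that bears an ethoxycarbonyl group.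

The step that the estimate means, a number 10.6 percentage points lower from compound 3 to compound 4 (beyond the scatter), is expected to resemble a number 10.6 percentage points lower from compound 1 to compound 2 (beyond the scatter), the step made by the same change between the two measured compounds. Compound 4 is therefore estimated to give 10.5% in this assay, with an expected range from 2% to 19%. For the measured compounds named here, whether the ethoxycarbonyl group alters the size of this step cannot be told from the compounds measured so far.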

Compound 4, a percentage reported as inhibition, in the whole organism at one dose (the size of the read-out at that dose, not a potency): 6.43%
Compound 4: the middle estimate sits 4.1 percentage points above what was measured; the range from low to high includes it.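

In this assay, for the compounds shown here, putting 4-chlorophenyl in place of 2-hydroxyphenyl gave a number 14.7 percentage points lower from compound 3 to compound 4 (beyond the scatter), and this step agrees with the one the same change made on the core without the ethoxycarbonyl group: the same change on two cores in this assay, a number 10.6 percentage points lower (beyond the scatter) from compound 1 to compound 2 and a number 14.7 percentage points lower (beyond the scatter) from compound 3 to compound 4, 4.1 percentage points apart, within the scatter of two such steps. The reverse view of the same four compounds gave a number 0.6 percentage points higher from compound 2 to compound 4 (within the scatter) for ethoxycarbonyl in place of hydrogen, and this step also agrees with its earlier counterpart on the 2-hydroxyphenyl compounds: the same change on two cores in this assay, a number 4.7 percentage points higher (within the scatter) from compound 1 to compound 3 and a number 0.6 percentage points higher (within the scatter) from compound 2 to compound 4, 4.1 percentage points apart, within the scatter of two such steps. So within this set, each change acts about the same whichever form the other position takes, but both comparisons rest on the same four compounds at a single oral dose, so they count as one test rather than two, and they show neither that the steps are exactly equal nor that either change would carry over to a different core.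

The swap removes the hydroxyl group and adds the chlorine at once, so these compounds cannot say which of the two goes with the lower numbers; an unsubstituted phenyl ring or a 4-hydroxyphenyl group could begin to separate them. From the compounds shown here alone, it also remains open whether the steps would hold with a carboxylic acid or an amide in place of the ethoxycarbonyl group.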